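The source may report more compounds than this note shows. Statements on the series, on what has been measured and on what is new or still open speak of the compounds shown alone.

Measured compounds, values from a functional assay on LOX IMVI cells (Homo sapiens) for cytotoxicity, read by sulforhodamine B assay, with a stated time of 48 h; a higher number here means a weaker inhibitor of growth, a lower number a stronger inhibitor of growth:
compound 1, `ClCc1ccc(Cn2cnc3c(Cl)ncnc32)cc1`, gives 3460 nM
compound 2, `Nc1nc(Cl)c2ncn(Cc3ccc(CCl)cc3)c2n1`, gives 43700 nM
compound 3, `ClCc1ccccc1Cn1cnc2c(Cl)ncnc21`, gives 5240 nM

Compound 1 and compound 3 are built from the same atoms joined differently; the difference between the two cores is not broken down here. In this assay compound 3 and compound 1 sit close together, and their gap lies within the scatter, so no order between them is drawn.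

Among the measured compounds shown here, the one structural change seen twice is amino in place of hydrogen on an aromatic carbon. Made on the core of compound 1, it gives compound 2, and in this assay the step is a 13-fold higher number from compound 1 to compound 2 (1.10 log units; beyond the scatter). This is the only measured instance of the change, and it was made on a different core from that of compound 3, so whether it carries over is not shown by any pair measured so far.

Compound 4, `Nc1nc(Cl)c2ncn(Cc3ccccc3CCl)c2n1`, is not yet measured. For the measured compounds named here, it differs from compound 3 by amino in place of hydrogen on an aromatic carbon, which is the same change at the same place as the one from compound 1 to compound 2. Going by the values given here, the step in this assay is expected to be of similar size, a 13-fold higher number from compound 3 to compound 4 (1.11 log units; beyond the scatter), resting on the single prior step a 13-fold higher number from compound 1 to compound 2 (1.10 log units; beyond the scatter). On that basis compound 4 is estimated at 68000 nM in this assay, with the likely range expected to run from 25000 nM to 160000 nM.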

Compound 4, concentration for total growth inhibition: 21900 nM
The estimate for compound 4 lay 3.1-fold (0.49 log units) above the measured number, and the stated range ends above it.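

On the core of compound 3, amino in place of hydrogen on an aromatic carbon gives in this assay a 4.2-fold higher number from compound 3 to compound 4 (0.62 log units; beyond the scatter), so the direction seen on the core of compound 1 carries over to this second core, and both amino compounds are weaker inhibitors of growth than their hydrogen counterparts. The size of the step does not carry over, and a step read on one core is therefore a guide to direction rather than a number to transfer unchanged: the two measured instances differ: the same change on two cores in this assay, a 13-fold higher number (1.10 log units; beyond the scatter) from compound 1 to compound 2 and a 4.2-fold higher number (0.62 log units; beyond the scatter) from compound 3 to compound 4, 3.0-fold (0.48 log units) apart, beyond the scatter of two such steps

These two pairs do not show what in the cores sets the size of the step, and with only two instances they give no rule for any further core in the series.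

The compounds shown leave open whether a methylamino group, a hydroxyl group or a methoxy group on the same aromatic carbon, between two ring nitrogen atoms, would move the number in the same direction as amino. On these data alone, it also remains open whether the chloro group on that ring could be replaced by an amine or a thioether without losing the activity seen in compound 1 and compound 3.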